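A few compounds are considered here, and "the series" means these few. Any claim that something is new, unique, unknown or untested is made for them only; others in the source may bear on it.

Three compounds built on one shared core have been examined in an assay on cells for inhibition of Amine oxidase [flavin-containing] A (Homo sapiens), read by Amplex Red, with a stated time of 30 min (a higher number here means a weaker inhibitor, a lower number a stronger inhibitor), and all three tell the same story. Compound 1 `O=C1COC(c2ccc(NCc3cccc(Cl)c3)cc2)=NN1` gives only the limit > 100000 nM, the edge of what the assay can report rather than a number. Compound 2 `O=C1COC(c2ccc(/N=N/c3ccc(Cl)cc3)cc2)=NN1` likewise stops at the limit > 100000 nM. Compound 3 `O=C1COC(c2ccc(/N=C/c3cccc(Cl)c3)cc2)=NN1`, the starting point here, also returns only the limit > 100000 nM. Compound 3 therefore stands exactly where its two companions stand, at the limit of > 100000 nM in this assay, at which 3 of the 3 values shown sit, with no measured number anywhere to set it apart from them.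

Compound 4 `O=C1COC(c2ccc(/N=C/c3ccc(Cl)cc3)cc2)=NN1` differs from compound 3 in a single place: 4-chlorophenyl in place of 3-chlorophenyl on a carbon with a double bond to nitrogen. Among the measured compounds shown here, no measured pair shows what such a swap does in this assay. Because compound 3 rests at the limit of > 100000 nM in this assay, at which 3 of the 3 values shown sit, the expected step is a number no higher from compound 3 to compound 4 (the limit leaves the size open), nothing beyond the ordinary scatter, and most probably another limit. Compound 4 is thus estimated at 100000 nM, with a range from 50000 nM to 300000 nM.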

Compound 4, half-maximal inhibitory concentration: > 100000 nM
Compound 4 gave a limit, no number; the forecaster's own chance of this, stated with the estimate: 85%; the middle value sits exactly at the limit.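

Compound 4 returns only a limit (> 100000 nM). Among the compounds shown here, compound 3 also sits at a limit, so no step between compound 3 and compound 4 can be read. Which change to the shared core, if any, would give a real number in this assay stays open, as every compound shown stops at the same edge: the limit of > 100000 nM in this assay, at which 4 of the 4 values shown sit.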